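This account rests on a few compounds, and the source may have more. Where it says the series, first, only, none or still open, it means among the compounds named here.

Compound 1 `O=C1C(N2CCCCC2)=CC(=O)c2c1nc1n2[C@H]2OC[C@@H](O)[C@H]2OC1` is the starting point for this step. In a functional assay on MCF7 cells (Homo sapiens) for inhibition, read by sulforhodamine B assay (a higher number here means a weaker inhibitor, a lower number a stronger inhibitor), compound 1 gives > 8000 nM, which is a limit of the measurement rather than a number. Among the three values shown so far, compound 1 therefore has no fixed place; it sits at the limit (the limit of > 8000 nM in this assay, at which 1 of the 3 values shown sits). Compound 2 `O=C1C=C(NC2CCCC2)C(=O)c2c1nc1n2[C@H]2OC[C@@H](O)[C@H]2OC1` carries a cyclopentyl group on an amine nitrogen. In this assay compound 2 gives > 16000 nM, again a limit, the one at the limit of > 16000 nM in this assay, at which 1 of the 3 values shown sits. Compound 3 `CCOc1ccc(NC2=CC(=O)c3nc4n(c3C2=O)[C@H]2OC[C@@H](O)[C@H]2OC4)cc1` is its close relative, and in this assay compound 3 gives 1430 nM. Going by the values given here, the one measured step here, an at least 11-fold lower number from compound 2 to compound 3 (1.04 log units; beyond the scatter), comes from placing 4-ethoxyphenyl in place of cyclopentyl on an amine nitrogen.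

Compound 4 `O=C1C(Nc2ccc(I)cc2)=CC(=O)c2c1nc1n2[C@H]2OC[C@@H](O)[C@H]2OC1` differs from compound 1 by (4-iodophenyl)amino in place of piperidin-1-yl on a double-bonded ring carbon. This change resembles the measured step in that a saturated nitrogen substituent gives way to an aryl amine, so the step from compound 2 to compound 3 is the one that bears on it. A step of similar direction is therefore expected, and it is estimated that an at least 5.3-fold lower number from compound 1 to compound 4 (0.72 log units; beyond the scatter). Compound 4 is expected to give about 1500 nM in this assay, with a likely range from 400 nM to 6000 nM.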

Compound 4, half-maximal inhibitory concentration: 3890 nM
Estimate against measurement, compound 4: 2.6-fold (0.41 log units) below; the range from low to high includes it.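

In this assay, replacing the piperidin-1-yl ring on the double-bonded ring carbon with (4-iodophenyl)amino gives an at least 2.0-fold lower number from compound 1 to compound 4 (0.31 log units; beyond the scatter). The earlier step showed a gain from an aromatic ring on an amine nitrogen only against a cyclopentyl group, whereas this one shows a lower number against a saturated ring attached directly through its own nitrogen, a swap that also brings in a hydrogen-bond donor. The size of this step is only a lower bound because compound 1 stands at a limit of the assay and not at a number: the limit of > 8000 nM in this assay, at which 1 of the 4 values shown sits.

On these data alone, three things change together in this swap: the ring becomes aromatic, the nitrogen gains a hydrogen, and an iodine enters, so the share of each in the step stays open. A plain phenylamino group or a (4-chlorophenyl)amino group on this ring carbon would help to separate the role of the iodine from that of the aromatic ring, and a cyclohexylamino group would help to separate the role of the amine hydrogen.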